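The source may hold more compounds than are shown below. What is called first, only, known or untested is meant among the compounds shown, and "the series" means these compounds.

In an ADME assay on cells (Mus musculus, strain BALB/C) for cytotoxicity, read by MTT assay, with a stated time of 24 h (a higher number here means that more compound is tolerated, a lower number that less compound is tolerated), two close relatives of the same shared core have been measured. Compound 1 `COc1ccc(/C=N/NC(=O)c2ccc(C)cc2O)cc1` gives 723000 nM, and compound 2 `Cc1ccc(C(=O)N/N=C/c2ccc(F)cc2)c(O)c1` gives 568000 nM. Compound 2 therefore stands on the lower of the two numbers, with compound 1 nearest; the gap between them is a 1.3-fold lower number from compound 1 to compound 2 (0.10 log units; within the scatter), so the two compounds cannot be told apart on this measure.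

The next compound, compound 3 `Cc1ccc(C(=O)N/N=C/c2ccc([N+](=O)[O-])cc2)c(O)c1`, differs from compound 2 at a single spot: nitro in place of fluoro on an aromatic carbon. Among the measured compounds shown here, the only step measured so far, from compound 1 to compound 2, also swapped one small group for another at that same aromatic carbon and moved the number by a 1.3-fold lower number from compound 1 to compound 2 (0.10 log units; within the scatter). For the measured compounds named here, that is the one step that bears on the present change, and it stayed inside the scatter. On this basis the expectation for compound 3 in this assay is a step of a 1.0-fold lower number from compound 2 to compound 3 (0.01 log units; within the scatter), that is, no movement beyond the scatter in either direction. Compound 3 is accordingly estimated at 550000 nM, with a range from 280000 nM to 1100000 nM.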

Compound 3, half-maximal cytotoxic concentration: 734000 nM
The estimate for compound 3 lay 1.3-fold (0.13 log units) below the measured number; the measured number falls inside the stated range.
By their numbers in this assay, from the lowest: compounds 2, 1 and 3 (each within the scatter of the next).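

This position, para to a large group on the aromatic ring, has now carried methoxy, fluoro and nitro, and this assay does not tell the three compounds apart. Nitro in place of fluoro gives a 1.3-fold higher number from compound 2 to compound 3 (0.11 log units; within the scatter), and nitro in place of methoxy gives a 1.0-fold higher number from compound 1 to compound 3 (0.01 log units; within the scatter), so this swap, in which nitro enters with 3 heavy atoms and 2 hydrogen-bond acceptors while fluoro leaves with 1 heavy atom and 0 hydrogen-bond acceptors, also stays within the scatter. No measurement is available that would explain how close these numbers lie.

From the compounds shown here alone, the three compounds differ only at this one spot, so it remains open whether an amine, a carboxylic acid or a longer chain placed here would also stay within the scatter. They also leave open whether a change elsewhere in the shared core would give a step beyond the scatter in this assay.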